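The compounds below may be only part of what the source reports. "The series", "measured", "known", "first", "only" and "open" are said of these compounds alone.

In a functional assay on MDA-MB-231 cells (Homo sapiens) for antiproliferative activity, read by MTT assay, with a stated time of 72 h (a lower number here means a stronger inhibitor, a higher number a weaker inhibitor), compound 2 `NC1=NC2(CCOCC2)N(OCCCOc2ccc(Cl)cc2)C(N)=N1` offers no number to start from, as its result reads "not determined" (no result reported). The change to compound 4 `NC1=NC2(CCOCC2)N(OCCCOc2ccccc2Cl)C(N)=N1` is 2-chlorophenyl in place of 4-chlorophenyl on an oxygen on a saturated carbon. The nearest evidence comes from two relatives with a different core. In this assay, compound 1 `NC1=NC2(CCSCC2)N(OCCCOc2cccc(Cl)c2)C(N)=N1` gives 130 nM, and compound 3 `NC1=NC2(CCSCC2)N(OCCCOc2ccc(Br)cc2)C(N)=N1` gives 440 nM. Within the data shown here, the only measured step, a 3.4-fold higher number from compound 1 to compound 3 (0.53 log units; beyond the scatter), puts 4-bromophenyl in place of 3-chlorophenyl. It is therefore not the same swap as the one made here, and it comes from another core, so it bears on this change only loosely. It does show that changing this group can shift the result by a modest amount. With no number for compound 2, no step size or direction can be expected in this assay. The expectation must instead lean on the values of the two relatives, with a wide margin for the change of core. For compound 4, the estimated value is 300 nM, with an expected range from 60 nM to 1500 nM.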

Compound 4, half-maximal inhibitory concentration: 1430 nM
For compound 4 the middle estimate is 4.8-fold (0.68 log units) below the measured one, within the range that was stated.
By their numbers in this assay, from the lowest: compound 1; then compound 3; then compound 4.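

With no number for compound 2, the step to compound 4 cannot be read in this assay and compound 4 differs from compound 1 and compound 3 in more than one place. Nothing available explains the value of compound 4. Still open, from the compounds shown here alone, is how 2-chlorophenyl compares with 4-chlorophenyl on this shared core.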